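Chloro to Bromo: Estimating Compound 4

A few compounds are considered here, and "the series" means these few. Any claim that something is new, unique, unknown or untested is made for them only; others in the source may bear on it.

Compound 3 `CCNC(=O)c1cc(Oc2ccc(NC(=O)c3cc4cccnc4n(-c4ccc(Cl)cc4)c3=O)cc2)ccn1` gives 250 nM in a functional assay on A549 cells (Homo sapiens) for antiproliferative activity, read by MTT assay, with a stated time of 72 h; a higher number here means a weaker inhibitor, a lower number a stronger inhibitor.
Compound 2 `CCNC(=O)c1cc(Oc2ccc(NC(=O)c3cc4cccnc4n(-c4ccc(F)cc4)c3=O)cc2)ccn1` gives 120 nM in this assay.
Compound 1 `CNC(=O)c1cc(Oc2ccc(NC(=O)c3cc4cccnc4n(-c4ccc(Br)cc4)c3=O)cc2)ccn1` gives 1050 nM in this assay.

Among these three, compound 3 stands second highest: compound 2 sits lower, and compound 1 higher. Compound 4 `CCNC(=O)c1cc(Oc2ccc(NC(=O)c3cc4cccnc4n(-c4ccc(Br)cc4)c3=O)cc2)ccn1` differs from compound 3 by bromo in place of chloro on an aromatic carbon. For the measured compounds named here, the only measured step at this position is a 2.1-fold higher number from compound 2 to compound 3 (0.32 log units; beyond the scatter), a swap of one halogen for another that raised the number modestly. Going by the values given here, compound 1, the one other compound carrying bromo, gives the highest number of the three, though no single-change step links it to compound 4. A modest rise beyond the scatter is therefore expected, a 1.8-fold higher number from compound 3 to compound 4 (0.26 log units; within the scatter). Compound 4 is estimated at 450 nM, with a likely range from 200 nM to 1100 nM.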

Compound 4, half-maximal inhibitory concentration: 910 nM
Estimate against measurement, compound 4: 2.0-fold (0.31 log units) below; the range from low to high includes it.
By their numbers in this assay, from the lowest: compound 2; then compound 3; then compounds 4 and 1 (each within the scatter of the next).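

In this assay, the halogen swaps at this position now form a series in which the number rises at each step: a 2.1-fold higher number from compound 2 to compound 3 (0.32 log units; beyond the scatter) and then a 3.6-fold higher number from compound 3 to compound 4 (0.56 log units; beyond the scatter) for a total of a 7.6-fold higher number from compound 2 to compound 4 (0.88 log units; beyond the scatter) across the series. The amide chain behaves differently among the bromo compounds, where a 1.2-fold lower number from compound 1 to compound 4 (0.06 log units; within the scatter) leaves no readable difference. Going by these compounds, whether a methoxy group or an amine in place of the halogen would continue this rise stays open, as does the effect of the same chain change on the fluoro compounds. No measurement here gives a cause for the rise.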